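Three Measured Compounds and One Untested Neighbour

A few compounds are considered here, and "the series" means these few. Any claim that something is new, unique, unknown or untested is made for them only; others in the source may bear on it.

compound 1 `N#Cc1ccccc1-n1cc(COc2cccc(NC(=O)Nc3ccc(Cl)c(C(F)(F)F)c3)c2)nn1` — 1970 nM
compound 2 `N#Cc1ccc(-n2cc(COc3cccc(NC(=O)Nc4ccc(Cl)c(C(F)(F)F)c4)c3)nn2)cc1` — 2980 nM
compound 3 `O=C(Nc1cccc(OCc2cn(-c3ccccc3F)nn2)c1)Nc1ccc(Cl)c(C(F)(F)F)c1` — 1520 nM

All three share one core and differ only in the phenyl group attached to an aromatic nitrogen. In a functional assay on HepG2 cells (Homo sapiens) for inhibition, read by MTT assay, with a stated time of 72 h (a lower number here means a stronger inhibitor, a higher number a weaker inhibitor), compound 3 gives 1520 nM, the lowest of the three numbers, yet its distance to the others is small: a 1.3-fold lower number from compound 1 to compound 3 (0.11 log units; within the scatter) and a 2.0-fold lower number from compound 2 to compound 3 (0.29 log units; within the scatter), so no ordering among them can be claimed. Moving the nitrile around the ring changed little as well: a 1.5-fold higher number from compound 1 to compound 2 (0.18 log units; within the scatter).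

Compound 4 `O=C(Nc1cccc(OCc2cn(-c3cccc(I)c3)nn2)c1)Nc1ccc(Cl)c(C(F)(F)F)c1` has not been measured. It differs from compound 3 in one place: 3-iodophenyl in place of 2-fluorophenyl on an aromatic nitrogen. Every step seen so far in this series replaces or relocates a single small substituent on that phenyl group, and each stayed within the scatter. The step to compound 4 is of the same kind, exchanging one substituted phenyl for another, so no shift beyond the scatter is expected in this assay in either direction. The expected step is a 1.2-fold higher number from compound 3 to compound 4 (0.07 log units; within the scatter). For compound 4 the estimated value is 1800 nM, with a range from 700 nM to 4500 nM.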

Compound 4, half-maximal inhibitory concentration: 4780 nM
Estimate against measurement, compound 4: 2.7-fold (0.42 log units) below; the measured number lies above the stated range.
By their numbers in this assay, from the lowest: compounds 3, 1, 2 and 4 (each within the scatter of the next, the first and the last beyond it).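

In this assay this position gives its first steps beyond the scatter, with a 3.1-fold higher number from compound 3 to compound 4 (0.50 log units; beyond the scatter) and a 2.4-fold higher number from compound 1 to compound 4 (0.38 log units; beyond the scatter) in the same direction, both modest, so exchanging one substituted phenyl for another here does not always leave the number in place. The effect is not uniform, however: a 1.6-fold higher number from compound 2 to compound 4 (0.21 log units; within the scatter) stays within the scatter, so 3-iodophenyl stands apart from 2-fluorophenyl and 2-cyanophenyl but not from 4-cyanophenyl, and compound 2 goes against any simple claim that 3-iodophenyl separates from every other group in the series. The leaving and entering groups match in every computed count, including heavy atoms, rings, hydrogen-bond donors and acceptors, so those counts do not separate them, and no measurement in hand accounts for the step.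

The compounds shown leave open whether the step follows the change from fluorine to iodine or the change in that atom's place on the phenyl ring, as the two change together here. They also leave open how the number responds when that phenyl group carries chlorine, bromine, an amine or a carboxylic acid.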